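This account rests on a few compounds, and the source may have more. Where it says the series, first, only, none or still open, it means among the compounds named here.

Compounds measured in an assay on microsomes from liver for inhibition of 3-hydroxy-3-methylglutaryl-coenzyme A reductase (Rattus norvegicus), read by scintillation counting, with stated times of 0.5 h and 0.75 h; a lower number here means a stronger inhibitor, a higher number a weaker inhibitor:
compound 1 `Cc1ccccc1CNC(=O)c1nc(-c2ccc(F)cc2)n(CC[C@@H](O)C[C@@H](O)CC(=O)O)c1C1CC1` gives 4.9 nM
compound 2 `O=C(O)C[C@H](O)C[C@H](O)CCn1c(-c2ccc(F)cc2)nc(C(=O)NCc2ccccc2F)c1C1CC1` gives 1.5 nM
compound 3 `COc1ccc(CNC(=O)c2nc(-c3ccc(F)cc3)n(CC[C@@H](O)C[C@@H](O)CC(=O)O)c2C2CC2)cc1` gives 1.2 nM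

Compound 3 holds the lowest of the three numbers; compound 2 sits within the scatter of it, compound 1 stands apart by a 4.1-fold lower number from compound 1 to compound 3 (0.61 log units; beyond the scatter). Compound 4 `COc1ccccc1CNC(=O)c1nc(-c2ccc(F)cc2)n(CC[C@@H](O)C[C@@H](O)CC(=O)O)c1C1CC1` differs from compound 3 by 2-methoxyphenyl in place of 4-methoxyphenyl on a saturated chain carbon bound to an amide-type nitrogen. Within the data shown here, no measured step moves a methoxy within the ring; the steps that bear on it are a 4.1-fold lower number from compound 1 to compound 3 (0.61 log units; beyond the scatter) and a 1.3-fold lower number from compound 2 to compound 3 (0.10 log units; within the scatter), where a 2-methylphenyl costs and a 2-fluorophenyl costs nothing beyond the scatter, while a 3.3-fold lower number from compound 1 to compound 2 (0.51 log units; beyond the scatter) separates those two. A modest rise in the number, or none beyond the scatter, is therefore expected, a 2.1-fold higher number from compound 3 to compound 4 (0.32 log units; beyond the scatter). Compound 4 is estimated at 2.5 nM, with a range from 1 nM to 8 nM.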

Compound 4, half-maximal inhibitory concentration: 7 nM
For compound 4 the middle estimate is 2.8-fold (0.45 log units) below the measured one, within the range that was stated.
By their numbers in this assay, from the lowest: compounds 3 and 2 (each within the scatter of the next); then compounds 1 and 4 (each within the scatter of the next).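

Moving the methoxy within the ring is not neutral in this assay: a 5.8-fold higher number from compound 3 to compound 4 (0.77 log units; beyond the scatter), the first measured change of position alone on this saturated chain carbon. With the ring place held, the group also counts: a 4.7-fold higher number from compound 2 to compound 4 (0.67 log units; beyond the scatter), while a 1.4-fold higher number from compound 1 to compound 4 (0.15 log units; within the scatter), so fluoro stands apart from both methoxy and methyl there. No measurement available here explains either step. Still open, going by these compounds, is whether a chloro or a hydroxyl in place of the methoxy of compound 4 would track compound 2 or compound 4.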